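The compounds below may be only part of what the source reports. "The series", "measured", "known", "first", "only" and "open" are said of these compounds alone.

Compound 1 `O=C(NC1CCN(Cc2cccc(Cl)c2)CC1)c1ccc2ccccc2c1`: 54 nM
Compound 2 `O=C(NC1CCN(Cc2ccc(Cl)cc2)CC1)c1ccc2ccccc2c1`: 37 nM
Compound 3 `O=C(NC1CCN(Cc2ccc(C(F)(F)F)cc2)CC1)c1ccc2ccccc2c1`: 84 nM

In an assay on isolated protein for displacement of a labelled ligand from D(4) dopamine receptor (Homo sapiens) (a lower number here means a stronger inhibitor, a higher number a weaker inhibitor), compound 3 has the highest number of the three. The step of a 1.6-fold higher number from compound 1 to compound 3 (0.19 log units; within the scatter) stays within the scatter, while the step of a 2.3-fold higher number from compound 2 to compound 3 (0.36 log units; beyond the scatter) lies beyond it. Compound 4 `Cc1cccc(CN2CCC(NC(=O)c3ccc4ccccc4c3)CC2)c1` differs from compound 3 by 3-methylphenyl in place of 4-(trifluoromethyl)phenyl on a saturated chain carbon bound to an amine nitrogen in a ring. Among the compounds with values here, two measured steps bear on this change: a 1.6-fold higher number from compound 1 to compound 3 (0.19 log units; within the scatter), read in reverse, and a 2.3-fold higher number from compound 2 to compound 3 (0.36 log units; beyond the scatter), both of which exchange trifluoromethyl and chloro groups. The 3-methylphenyl of compound 4 most closely matches the 3-chlorophenyl of compound 1, so a modest lower number is expected, a 1.5-fold lower number from compound 3 to compound 4 (0.18 log units; within the scatter), though it may well fall within the scatter. The estimate for compound 4 in this assay is 55 nM, with a range from 25 nM to 120 nM.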

Compound 4, inhibition constant: 11 nM
Estimate against measurement, compound 4: 5.0-fold (0.70 log units) above; measured number outside the range, below it.
By their numbers in this assay, from the lowest: compound 4; then compounds 2, 1 and 3 (each within the scatter of the next, the first and the last beyond it).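

In this assay, within the data shown here, the aromatic group on the saturated chain carbon bound to an amine nitrogen in a ring proves more consequential than the earlier compounds suggested: methyl in place of chloro gives a 4.9-fold lower number from compound 1 to compound 4 (0.69 log units; beyond the scatter). The 3-methylphenyl group also stands clear of the other two groups, with a 3.4-fold lower number from compound 2 to compound 4 (0.53 log units; beyond the scatter) and a 7.6-fold lower number from compound 3 to compound 4 (0.88 log units; beyond the scatter), making compound 4 the strongest inhibitor of the four. No measurement available here explains this gain. The compounds shown leave open whether an ethyl or a methoxy group on this aromatic ring would retain it.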